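A Fluoro for Aminomethyl Swap on a Shared Core

The source may report more compounds than this note shows. Statements on the series, on what has been measured and on what is new or still open speak of the compounds shown alone.

Of the compounds shown here, two have been measured in an assay on isolated protein for inhibition of GMP reductase 2 (Homo sapiens), read by spectrophotometry; on this read-out higher numbers stand for weaker inhibition and lower numbers for stronger inhibition. Compound 1, `COc1ccc(Cc2nc3cc(NC(=O)[C@H](C)Oc4cccc(Cl)c4Cl)ccc3o2)cc1`, gives only a limit in this assay, > 5000 nM. Compound 2, `C[C@H](Oc1cccc(Cl)c1Cl)C(=O)Nc1ccc2oc(-c3ccc(CN)cc3)nc2c1`, likewise reaches only a limit in this assay, > 5000 nM. Within the data shown here, the one recorded step, a step that the two limits leave unreadable from compound 1 to compound 2, therefore cannot be sized, and the limit of > 5000 nM in this assay, at which 2 of the 2 values shown sit, shows that both values sit at the same limit.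

Compound 3, `C[C@H](Oc1cccc(Cl)c1Cl)C(=O)Nc1ccc2oc(-c3ccc(F)cc3)nc2c1`, differs from compound 2 in one place: fluoro in place of aminomethyl on an aromatic carbon. The group that leaves is an aminomethyl; the group that enters is a fluoro, on an aromatic carbon of a six-membered aromatic ring of carbon only, para to a large group.

Among the measured compounds shown here, no measured step bears on this change; the only step available runs between two limits. Compound 2 stands at a limit, and nothing in the data points to a shift in either direction beyond the scatter. Compound 3 is therefore expected to remain near that limit as well. The step that the limit leaves unreadable from compound 2 to compound 3 is estimated to be small. Compound 3 is estimated at 6000 nM, within 2000 nM to 20000 nM.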

Compound 3, inhibition constant: > 5000 nM
Compound 3 gave a limit, no number (the forecaster's own chance of this, stated with the estimate: 70%); the middle value lies beyond the limit too.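

Compound 3 gives only a limit in this assay, > 5000 nM. The steps among compound 1, compound 2 and compound 3 therefore cannot be read: the limit of > 5000 nM in this assay, at which 3 of the 3 values shown sit. The compounds shown leave open how strongly any of the three inhibits in this assay, and so what the exchanged groups on the shared core do to inhibition.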